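Pyridyl swap on a cytotoxicity read-out: expected step for compound 4

This account rests on a few compounds, and the source may have more. Where it says the series, first, only, none or still open, it means among the compounds named here.

Measured so far:
compound 1 `COc1cc(/C=C2\CN(C)C/C(=C\c3cccnc3)C2=O)cc(OC)c1`: 18400 nM
compound 2 `COc1ccc(/C=C2\CN(C)C/C(=C\c3cccnc3)C2=O)c(OC)c1OC`: 13600 nM
compound 3 `COc1cc(/C=C2\CN(C)C/C(=C\c3ccncc3)C2=O)cc(OC)c1`: 13400 nM

In an ADME assay on L02 cells (Homo sapiens) for cytotoxicity, read by MTT assay, with a stated time of 24 h (on this read-out higher numbers stand for weaker inhibition and lower numbers for stronger inhibition), compound 1 gives 18400 nM and compound 3 gives 13400 nM. The change between them, (pyridin-4-yl in place of pyridin-3-yl on a double-bonded chain carbon bound to a double-bonded ring carbon), made a step of a 1.4-fold lower number from compound 1 to compound 3 (0.14 log units; within the scatter). Compound 2 gives 13600 nM in this assay; how its core differs from that of compound 1 is not broken down here, and the two values lie within the scatter of each other. Compound 4 `COc1ccc(/C=C2\CN(C)C/C(=C\c3ccncc3)C2=O)c(OC)c1OC` has not yet been measured. It differs from compound 2 by pyridin-4-yl in place of pyridin-3-yl on a double-bonded chain carbon bound to a double-bonded ring carbon, the same change seen between compound 1 and compound 3. Because that earlier step was a 1.4-fold lower number from compound 1 to compound 3 (0.14 log units; within the scatter), the step from compound 2 to compound 4 is expected to be of similar small size, a 1.2-fold lower number from compound 2 to compound 4 (0.09 log units; within the scatter). Compound 4 is therefore estimated at 11000 nM in this assay, with a range from 5000 nM to 25000 nM.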

Compound 4, half-maximal inhibitory concentration: 15600 nM
Beside the measured number, compound 4's estimate is 1.4-fold (0.15 log units) below it, and the stated range covers the measured number.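

In this assay, pyridin-4-yl in place of pyridin-3-yl gives a 1.1-fold higher number from compound 2 to compound 4 (0.06 log units; within the scatter). Set beside the earlier step, the change shows no difference between the two cores: the same change on two cores in this assay, a 1.4-fold lower number (0.14 log units; within the scatter) from compound 1 to compound 3 and a 1.1-fold higher number (0.06 log units; within the scatter) from compound 2 to compound 4, 1.6-fold (0.20 log units) apart, within the scatter of two such steps. The change therefore carries from one core to the other only as a step too small to read, with no reliable direction, and these two pairs show neither that it is without effect on other cores nor that the two steps are truly identical.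

The compounds shown leave open whether a larger step would appear with an amine or a carboxylic acid on that chain in place of the pyridine ring. They also leave open whether a longer chain there would move the number beyond the scatter.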